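A piperidin-1-yl group replaces cyclobutylmethyl on the carbonyl

A few compounds are considered here, and "the series" means these few. Any claim that something is new, unique, unknown or untested is made for them only; others in the source may bear on it.

In a physicochemical assay for solubility, read by HPLC, in phosphate buffer, measured as kinetic solubility, at pH 7.4 (on this read-out lower numbers stand for lower solubility and higher numbers for higher solubility), compound 1 `CCC(=O)c1cc(-c2ccc(S(N)(=O)=O)cc2)n(-c2ccc(Cl)cc2)n1` gives 41900 nM, while compound 2 `NS(=O)(=O)c1ccc(-c2cc(C(=O)CC3CCC3)nn2-c2ccc(Cl)cc2)cc1` gives 4300 nM, the lower of the two numbers. Compound 3 `NS(=O)(=O)c1ccc(-c2cc(C(=O)N3CCCCC3)nn2-c2ccc(Cl)cc2)cc1` carries piperidin-1-yl in place of cyclobutylmethyl on a carbonyl carbon. Within the data shown here, the only measured step that bears on this is a 9.7-fold lower number from compound 1 to compound 2 (0.99 log units; beyond the scatter), a modest change beyond the scatter. That step involved no piperidin-1-yl, so it offers only a loose guide. No shift beyond the scatter is therefore expected in this assay, with the estimated step being a 1.4-fold higher number from compound 2 to compound 3 (0.14 log units; within the scatter). For compound 3 the expected value is 6000 nM, with an estimated range of 1800 nM to 20000 nM.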

Compound 3, solubility: 65900 nM
For compound 3 the middle estimate is 11-fold (1.04 log units) below the measured one; the whole stated range lies below it.
By their numbers in this assay, from the lowest: compound 2; then compounds 1 and 3 (each within the scatter of the next).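

In this assay this position proves sensitive to the group on the carbonyl carbon: piperidin-1-yl in place of cyclobutylmethyl gives a 15-fold higher number from compound 2 to compound 3 (1.19 log units; beyond the scatter) and so reverses the drop seen with cyclobutylmethyl. Piperidin-1-yl in place of ethyl gives a 1.6-fold higher number from compound 1 to compound 3 (0.20 log units; within the scatter) and leaves those two groups indistinguishable here. No measurement at hand accounts for the large step. Still open, going by these compounds, is whether the nitrogen or the six-membered ring matters: a diethylamino or a cyclohexyl group on the same carbonyl carbon would separate the two.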